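Thiourea sulfonamide quinazolines: anilino variation and A-431 growth

The source may report more compounds than this note shows. Statements on the series, on what has been measured and on what is new or still open speak of the compounds shown alone.

compound 1 `NS(=O)(=O)c1ccc(NC(=S)Nc2ccc3ncnc(Nc4cccc(Br)c4)c3c2)cc1`: 20700 nM
compound 2 `NS(=O)(=O)c1ccc(NC(=S)Nc2ccc3ncnc(Nc4cccc(Cl)c4)c3c2)cc1`: 15000 nM

Both compounds were run in a functional assay on A-431 cells (Homo sapiens) for antiproliferative activity, read by MTT assay, with a stated time of 72 h; a higher number here means a weaker inhibitor, a lower number a stronger inhibitor. Compound 2 holds the lowest of the two numbers, with compound 1 nearest; the step of a 1.4-fold lower number from compound 1 to compound 2 (0.14 log units; within the scatter) is within the scatter. Compound 3 `Cc1ccc(Nc2ncnc3ccc(NC(=S)Nc4ccc(S(N)(=O)=O)cc4)cc23)cc1` has not been measured in this assay. It differs from compound 2 in one place: 4-methylphenyl in place of 3-chlorophenyl on a nitrogen on an aromatic ring. For the measured compounds named here, the only measured step concerns a halogen swap on the same ring and does not bear directly on this change, so no step beyond the scatter is expected in this assay. Compound 3 is estimated at 20000 nM, range 7000 nM to 60000 nM, meaning an expected step of a 1.3-fold higher number from compound 2 to compound 3 (0.12 log units; within the scatter).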

Compound 3, half-maximal inhibitory concentration: 40000 nM
Beside the measured number, compound 3's estimate is 2.0-fold (0.30 log units) below it; low and high end bracket the measured number.
By their numbers in this assay, from the lowest: compounds 2, 1 and 3 (each within the scatter of the next, the first and the last beyond it).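

In this assay, for the compounds shown here, the group on the nitrogen gives the first step beyond the scatter (a 2.7-fold higher number from compound 2 to compound 3 (0.43 log units; beyond the scatter)), so this position is not flat across every change. The same change measured against 3-bromophenyl (a 1.9-fold higher number from compound 1 to compound 3 (0.29 log units; within the scatter)) stays within the scatter, so the signal is modest and rests on the 3-chlorophenyl comparison alone. Nothing available bears on the reason for this step.

The change alters both the substituent and where it sits on the ring, and these two cannot be separated here. From the compounds shown here alone, how an unsubstituted phenyl, or a ring carrying an amine or a methoxy group, would read at this position remains open.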